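Furan isomer swap in a biaryl aminobenzonitrile series

A few compounds are considered here, and "the series" means these few. Any claim that something is new, unique, unknown or untested is made for them only; others in the source may bear on it.

Measured compounds:
compound 1, `N#Cc1ccc(N2CCc3cc(-c4cncnc4)ccc32)cc1C(F)(F)F`: "not determined" (no result reported) in a functional assay on CWR22R cells (Homo sapiens) for antiproliferative activity, read by CCK-8 assay, with a stated time of 6 days; on this read-out higher numbers stand for weaker inhibition and lower numbers for stronger inhibition
compound 2, `CCN(c1ccc(C#N)c(Cl)c1)c1cc(-c2ccoc2)ccc1C`: > 30000 nM
compound 3, `CCN(c1ccc(C#N)c(Cl)c1)c1cc(-c2ccco2)ccc1C`: awaiting measurement

For compound 1 no number exists in this assay; the entry reads "not determined" (no result reported). Compound 2 sits at the limit of this assay, given as > 30000 nM, so it too yields no single number. Among the two entries shown, compound 2 thus stands at the limit of > 30000 nM in this assay, at which 1 of the 2 values shown sits, and nothing places it anywhere else on the scale. Compound 3 differs from compound 2 in a single point, (furan-2-yl in place of furan-3-yl on an aromatic carbon), with furan-2-yl entering where furan-3-yl leaves. Among the compounds with values here, no step between measured compounds is available to anchor this change. Because compound 2 is recorded only at the limit of > 30000 nM in this assay, at which 1 of the 2 values shown sits, a move beyond the scatter in either direction is not expected, and the step of a number no higher from compound 2 to compound 3 (the limit leaves the size open) is estimated as essentially none. Compound 3 is therefore expected near 30000 nM, within 10000 nM to 100000 nM, most likely reported again as a limit.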

Compound 3, half-maximal inhibitory concentration: > 30000 nM
Compound 3 gave a limit, no number (the forecaster's own chance of this, stated with the estimate: 75%); the middle value lies on the limit itself.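

In this assay, compound 2 and compound 3 each give only a limit, not a number, so the step from furan-3-yl to furan-2-yl cannot be read: the limit of > 30000 nM in this assay, at which 2 of the 3 values shown sit. The compounds shown leave open how furan-2-yl and furan-3-yl would compare on a measurable part of the scale.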